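The compounds below may be only part of what the source reports. "The series", "measured", "known", "first", "only" and "open" are said of these compounds alone.

Measured compounds:
Compound 1 `CN(C(=O)NC(=O)c1ccc(F)c(F)c1)c1nc(C(F)(F)F)c(C(=O)N/N=C/c2ccccc2C(F)(F)F)s1` gives 8.21 ug/mL in a functional assay on MCF7 cells (Homo sapiens) for inhibition, read by MTT assay, with a stated time of 72 h; on this read-out higher numbers stand for weaker inhibition and lower numbers for stronger inhibition.
Compound 3 `CN(C(=O)NC(=O)c1ccc(F)c(F)c1)c1nc(C(F)(F)F)c(C(=O)N/N=C/c2ccc([N+](=O)[O-])cc2)s1` gives 4.81 ug/mL in this assay.
Compound 2 `CN(C(=O)NC(=O)c1ccc(Cl)cc1Cl)c1nc(C(F)(F)F)c(C(=O)N/N=C/c2cc(C(F)(F)F)cc(C(F)(F)F)c2)s1` gives only a limit, > 100 ug/mL, in this assay.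

Among the compounds with values here, compound 1 stands at the higher of the two numbers actually obtained; its nearest neighbour is compound 3, and the only single-point step recorded, a 1.7-fold lower number from compound 1 to compound 3 (0.23 log units; within the scatter), lies within the scatter. The third value, that of compound 2, is a limit of > 100 ug/mL in this assay, at which 1 of the 3 values shown sits, and not a number, and compound 2 differs from compound 1 in two places at once, so it yields no single-point comparison.

The unmeasured compound 4 `CN(C(=O)NC(=O)c1ccc(C(F)(F)F)cc1)c1nc(C(F)(F)F)c(C(=O)N/N=C/c2ccccc2C(F)(F)F)s1` differs from compound 1 in one place: 4-(trifluoromethyl)phenyl in place of 3,4-difluorophenyl on a carbonyl carbon. Within the data shown here, no measured step touches this carbonyl-bound aryl group; the one step on record, a 1.7-fold lower number from compound 1 to compound 3 (0.23 log units; within the scatter), concerns the other aryl group of the shared core and was within the scatter. There is therefore nothing in the data pointing to a change beyond the scatter in either direction, and the expected step of a 1.2-fold higher number from compound 1 to compound 4 (0.09 log units; within the scatter) is set near zero, with a wide range to reflect the absence of any direct precedent. Compound 4 is expected to give about 10 ug/mL in this assay, within roughly 3 ug/mL to 35 ug/mL.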

Compound 4, half-maximal inhibitory concentration: 2.21 ug/mL
Compound 4: the middle estimate sits 4.5-fold (0.66 log units) above what was measured; measured number below the stated range.
By their numbers in this assay, from the lowest: compound 4; then compounds 3 and 1 (each within the scatter of the next). At a limit, above all of these: compound 2.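

In this assay, the aryl group on the carbonyl carbon whose other neighbour is the amide-type nitrogen proves able to move the read-out: 4-(trifluoromethyl)phenyl in place of 3,4-difluorophenyl gives a 3.7-fold lower number from compound 1 to compound 4 (0.57 log units; beyond the scatter), which stands for stronger inhibition and is the only single-place step shown that lies beyond the scatter. The earlier step, a 1.7-fold lower number from compound 1 to compound 3 (0.23 log units; within the scatter), changed the other aryl group of the shared core and stayed within the scatter, so until now no single change had separated two compounds in this assay. The new step remains modest and rests on one pair of compounds, and nothing measured here bears on its cause.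

As far as these compounds go, it remains open whether the lower number follows from the arrival of the trifluoromethyl group or from the departure of the two fluorines, and a phenyl ring carrying a single fluorine, a chlorine, a methoxy group, a nitrile or an amine in that place would help to tell these apart. From the compounds shown here alone, it also remains open whether the same change would give a similar step when the 4-nitrophenyl group of compound 3 stands on the other side of the core.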